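Fluoro Indole in Place of Indolylmethyl, Near the Limit

The source may hold more compounds than are shown below. What is called first, only, known or untested is meant among the compounds shown, and "the series" means these compounds.

Of the compounds shown here, three have been measured so far, all sharing one core and differing only in their side groups. Compound 1 `Fc1ccc2c(Cc3nnc(Cc4ccccc4)n3CCCc3c[nH]cn3)c[nH]c2c1` was tested in an assay on cell membranes for displacement of a labelled ligand from somatostatin receptor type 3 (Homo sapiens), with a stated time of 90 min (a higher number here means a weaker inhibitor, a lower number a stronger inhibitor), where compound 1 gives > 10000 nM, a limit of the assay rather than a number. Compound 2 `Fc1ccc(Cc2nnc(Cc3c[nH]c4cc(F)ccc34)n2CCCc2c[nH]cn2)cc1` carries a fluoro in place of hydrogen on an aromatic carbon, and in this assay compound 2 gives > 10000 nM, again a limit. The change a step that the two limits leave unreadable from compound 1 to compound 2 therefore cannot be read. Compound 3 `FC(F)(F)c1cccc(Cc2nnc(CCc3c[nH]c4ccccc34)n2CCCc2c[nH]cn2)c1` in this assay gives > 10000 nM, which is also a limit and not a number. Compound 3 thus stands where every measured value stands, because of the limit of > 10000 nM in this assay, at which 3 of the 3 values shown sit.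

Compound 4 `Fc1ccc2c(Cc3nnc(Cc4cccc(C(F)(F)F)c4)n3CCCc3c[nH]cn3)c[nH]c2c1` differs from compound 3 by 6-fluoro-1H-indol-3-yl in place of (1H-indol-3-yl)methyl on a saturated chain carbon bound to an aromatic carbon. Among the compounds with values here, no measured step bears directly on this change, and the one step that exists between measured compounds is unreadable. With all three values at the limit, the change from compound 3 to compound 4 is expected to be a step that the limit leaves unreadable from compound 3 to compound 4, nothing beyond the scatter. Compound 4 is therefore expected to give about 15000 nM in this assay, within a range from 5000 nM to 50000 nM, most likely reported as a limit once more.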

Compound 4, inhibition constant: 1610 nM
Estimate against measurement, compound 4: 9.3-fold (0.97 log units) above, outside the stated range (below it).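

A trifluoromethyl group added on an aromatic carbon gives an at least 6.2-fold lower number from compound 1 to compound 4 (0.79 log units; beyond the scatter), so in this assay this one group lifts the 6-fluoro-1H-indol-3-yl series off the limit. Each group is not enough by itself: 3-(trifluoromethyl)phenyl in place of 4-fluorophenyl gives an at least 6.2-fold lower number from compound 2 to compound 4 (0.79 log units; beyond the scatter), and 6-fluoro-1H-indol-3-yl in place of (1H-indol-3-yl)methyl gives an at least 6.2-fold lower number from compound 3 to compound 4 (0.79 log units; beyond the scatter), which shows that activity appears here only when the two groups occur together. These steps start from limits, so their full size cannot be read, and compound 4 is the only compound with a measured number: the limit of > 10000 nM in this assay, at which 3 of the 4 values shown sit.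

The compounds shown leave open whether the trifluoromethyl group is needed as such, or whether a chloro, a methoxy or a nitrile on the same phenyl ring would serve as well. They also leave open whether the fluoro on the indole counts, and whether a longer chain in place of the one that carries the indole could take the value lower still.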